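The source may hold more compounds than are shown below. What is called first, only, known or untested is meant among the compounds shown, and "the series" means these compounds.

Compound 3 `CCCCCCCCc1ccc(OCC(=O)Cn2nnc(-c3cccc(C(=O)OC)c3)n2)cc1` gives 34 nM in an assay on microsomes from brain for inhibition of Fatty-acid amide hydrolase 1 (Rattus norvegicus), read by fluorescence and HPLC, with a stated time of 60 min; on this read-out lower numbers stand for stronger inhibition and higher numbers for weaker inhibition; by rank alone this is the second highest of the three numbers, though all three sit within the scatter of one another. Compound 2 `CCCCCCCCc1ccc(OCC(=O)Cn2nnc(-c3ccc(Cl)cc3)n2)cc1` gives 35 nM and compound 1 `CCCCCCCCc1ccc(OCC(=O)Cn2nnc(SC)n2)cc1` gives 31 nM in this assay. Compound 4 `CCCCCCCCc1ccc(OCC(=O)Cn2nnc(-c3ccncc3)n2)cc1` differs from compound 3 in one place: pyridin-4-yl in place of 3-(methoxycarbonyl)phenyl on an aromatic carbon. Among the measured compounds shown here, the steps that bear on this swap are a 1.1-fold higher number from compound 1 to compound 2 (0.05 log units; within the scatter), a 1.1-fold higher number from compound 1 to compound 3 (0.04 log units; within the scatter) and a 1.0-fold lower number from compound 2 to compound 3 (0.01 log units; within the scatter), each within the scatter. Three quite different groups at this spot gave numbers within the scatter of one another, so no step beyond the scatter is expected for pyridin-4-yl, and the estimated step is a 1.0-fold higher number from compound 3 to compound 4 (0.01 log units; within the scatter). Compound 4 is expected to give 35 nM, with a range from 17 nM to 75 nM.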

Compound 4, half-maximal inhibitory concentration: 24 nM
Compound 4: the middle estimate sits 1.5-fold (0.16 log units) above what was measured; the measured number falls inside the stated range.
By their numbers in this assay, from the lowest: compounds 4, 1, 3 and 2 (each within the scatter of the next).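

In this assay the swap to pyridin-4-yl gives a 1.4-fold lower number from compound 3 to compound 4 (0.15 log units; within the scatter) and a 1.5-fold lower number from compound 2 to compound 4 (0.16 log units; within the scatter) and a 1.3-fold lower number from compound 1 to compound 4 (0.11 log units; within the scatter) and all three steps stay within the scatter. This position on the five-membered ring therefore also accepts a six-membered aromatic ring with a ring nitrogen, with no step beyond the scatter among the four groups shown. Nothing given here explains this flat result. Still open, as far as these compounds go, is whether an amine or a carboxylic acid on this aromatic carbon would leave the number just as level. Pyridin-2-yl, with its ring nitrogen placed differently, is open too.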